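A few compounds are considered here, and "the series" means these few. Any claim that something is new, unique, unknown or untested is made for them only; others in the source may bear on it.

Measured in a functional assay on DU-145 cells (Homo sapiens) for cytotoxicity, read by sulforhodamine B assay, with a stated time of 48 h; on this read-out lower numbers stand for higher toxicity in this test and higher numbers for lower toxicity in this test:

compound 1 `CCN1CCN(c2nc(Nc3ccc(C#N)c(C(F)(F)F)c3)nc(Oc3ccnc4ccccc34)n2)CC1`: > 100000 nM
compound 2 `N#Cc1ccc(Nc2nc(Oc3ccnc4ccccc34)nc(N3CCN(c4ccccn4)CC3)n2)cc1C(F)(F)F`: > 100000 nM
compound 3 `N#Cc1ccc(Nc2nc(Oc3ccnc4ccccc34)nc(N3CCN(c4ncccn4)CC3)n2)cc1C(F)(F)F`: > 100000 nM

Compound 3 stands at the limit of this assay and not at a number. The same holds for the other two: all three values sit at the ceiling, as noted in the limit of > 100000 nM in this assay, at which 3 of the 3 values shown sit. For the measured compounds named here, nothing is therefore ranked, and none of the measured steps can be read. The change from ethyl to pyridin-2-yl on the ring amine nitrogen, a step that the two limits leave unreadable from compound 1 to compound 2, the change from ethyl to pyrimidin-2-yl, a step that the two limits leave unreadable from compound 1 to compound 3, and the change from pyridin-2-yl to pyrimidin-2-yl, a step that the two limits leave unreadable from compound 2 to compound 3, all stay hidden behind the two limits.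

Compound 4 `N#Cc1ccc(Nc2nc(Oc3ccnc4ccccc34)nc(N3CCN(c4ccccc4F)CC3)n2)cc1C(F)(F)F` is the next variation at the same place: 2-fluorophenyl in place of pyrimidin-2-yl on an amine nitrogen in a ring. The measured steps bearing on this position are the three above, and none gives a size, so no direction beyond the scatter can be expected in this assay from this information. The working assumption is that the group on the ring amine nitrogen changes little here. Compound 4 is therefore estimated at 100000 nM, with a range from 30000 nM to 300000 nM, most likely reported again as a limit. The expected step of a number no higher from compound 3 to compound 4 (the limit leaves the size open) is thus essentially none.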

Compound 4, concentration lethal to 50% of the cells: > 100000 nM
Compound 4: a limit, no number (the forecaster's own chance of this, stated with the estimate: 75%); the middle value sits exactly at the limit.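

In this assay compound 4 gives > 100000 nM, a limit and not a number. No step from compound 1, compound 2 or compound 3 to compound 4 can be read: the limit of > 100000 nM in this assay, at which 4 of the 4 values shown sit.

The compounds shown leave open whether the group on the ring amine nitrogen affects the read-out at all.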